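Ester to Acyl Carbamate: Expected Cytotoxicity of Compound 3

The source may report more compounds than this note shows. Statements on the series, on what has been measured and on what is new or still open speak of the compounds shown alone.

In an ADME assay on RAW264.7 cells (Mus musculus) for cytotoxicity, read by WST assay (on this read-out lower numbers stand for higher toxicity in this test and higher numbers for lower toxicity in this test), compound 1 `CC1=C(c2ccc3ccccc3c2)S(=O)(=O)N(Cc2ccc(C(=O)N3CCCCC3)cc2)C1=O` gives 47900 nM. Compound 2 `CC(C)(C)OC(=O)c1ccc(CN2C(=O)c3ccccc3S2(=O)=O)cc1` gives > 100000 nM in this assay, which is a limit of the assay and not a number; this is the limit of > 100000 nM in this assay, at which 1 of the 2 values shown sits. Compound 3 `CC(C)(C)OC(=O)NC(=O)c1ccc(CN2C(=O)c3ccccc3S2(=O)=O)cc1` differs from compound 2 in one place: (tert-butoxycarbonyl)amino in place of tert-butoxy on a carbonyl carbon. Going by the values given here, no measured step covers this change, so no shift beyond the usual scatter is expected in this assay, in either direction. Compound 3 is therefore expected to give about 100000 nM, with a range from 45000 nM to 220000 nM. The expected step is a number no higher from compound 2 to compound 3 (the limit leaves the size open), and the assay may again report only a limit.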

Compound 3, concentration lethal to 50% of the cells: > 100000 nM
Compound 3: only a limit was reported; the forecaster's own chance of this, stated with the estimate: 65%; the middle value sits exactly at the limit.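

Going by these compounds alone, no step from compound 2 to compound 3 can be read, since both results are limits of the assay and not numbers: the limit of > 100000 nM in this assay, at which 2 of the 3 values shown sit. In this assay the compounds shown leave open whether (tert-butoxycarbonyl)amino in place of tert-butoxy on a carbonyl carbon shifts the read-out at all.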